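A few compounds are considered here, and "the series" means these few. Any claim that something is new, unique, unknown or untested is made for them only; others in the source may bear on it.

Compound 1 `O=S(=O)(c1cccc(F)c1)c1cnc2cc(F)ccc2c1-c1ccc(F)cc1`: 0.11 mL/min
Compound 2 `O=S(=O)(c1ccc(F)c(F)c1)c1cnc2cc(F)ccc2c1-c1cccc(F)c1`: 0.6 mL/min

In an ADME assay on microsomes from liver (Homo sapiens) for metabolic stability, tested at 2.5 uM (a higher number here means faster removal of the compound, a lower number slower removal), compound 2 stands highest of the two numbers: compound 1 gives 0.11 mL/min, and compound 2 gives 0.6 mL/min, a gap beyond the scatter.

Compound 3 `O=S(=O)(c1cccc(F)c1)c1cnc2cc(F)ccc2c1-c1cccc(F)c1` is not yet measured. It differs from compound 2 by hydrogen in place of fluoro on an aromatic carbon. Within the data shown here, no measured pair isolates this change. Compound 3 is expected to come in at 0.3 mL/min, within 0.1 mL/min to 0.9 mL/min. The expected step of a 2.0-fold lower number from compound 2 to compound 3 (0.30 log units; within the scatter) runs downward, likely beyond the scatter, because compound 1 gives 0.11 mL/min while carrying the same 3-fluorophenyl on its sulfonyl side.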

Compound 3, intrinsic clearance in a liver preparation (reported as CLH), per the amount of preparation that the assay uses: 0.24 mL/min
The estimate for compound 3 lay 1.3-fold (0.10 log units) above the measured number; low and high end bracket the measured number.
By their numbers in this assay, from the lowest: compound 1; then compound 3; then compound 2.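

In this assay the change from 3,4-difluorophenyl to 3-fluorophenyl is now measured on its own, giving a 2.5-fold lower number from compound 2 to compound 3 (0.40 log units; beyond the scatter) and showing that this single fluoro, para to a large group, counts beyond the scatter. Putting 3-fluorophenyl in place of 4-fluorophenyl gives a 2.2-fold higher number from compound 1 to compound 3 (0.34 log units; beyond the scatter) as a modest step of similar size, so a second place on the shared core also moves the number. Nothing measured here accounts for either step.

Still open, on these data alone, is whether a chloro or methoxy group in place of this fluoro would move the number, and in which direction.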